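Oxadiazole in Place of Fluoro: Expected Potency Shift

This account rests on a few compounds, and the source may have more. Where it says the series, first, only, none or still open, it means among the compounds named here.

Compound 1 `CC(C)(C)c1ccc(NC(=O)c2ccc(-c3ncccc3F)cc2)cc1` gives 1 nM in a functional assay for antagonist activity at transient receptor potential cation channel subfamily V member 1 (Rattus norvegicus) (on this read-out lower numbers stand for stronger inhibition and higher numbers for weaker inhibition), the lowest of the two measured numbers. Going by the values given here, its nearest neighbour, compound 2 `CC(C)(C)c1ccc(NC(=O)c2ccc(-c3ncccc3C(=O)O)cc2)cc1`, gives 560 nM in this assay, and the step of a 560-fold higher number from compound 1 to compound 2 (2.75 log units; beyond the scatter) is the only measured step. Compound 3 `CC(C)(C)c1ccc(NC(=O)c2ccc(-c3ncccc3-c3nnco3)cc2)cc1` differs from compound 1 by 1,3,4-oxadiazol-2-yl in place of fluoro on an aromatic carbon. That lone step bears on this change only loosely, since the entering group carries no charge and no donor, so a loss as large as that of compound 2 is not expected, though some loss is estimated: a 30-fold higher number from compound 1 to compound 3 (1.48 log units; beyond the scatter). Compound 3 is therefore estimated at 30 nM, within a range from 4 nM to 300 nM.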

Compound 3, half-maximal inhibitory concentration: 59 nM
Compound 3: the middle estimate sits 2.0-fold (0.29 log units) below what was measured; the range from low to high includes it.
By their numbers in this assay, from the lowest: compound 1; then compound 3; then compound 2.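

In this assay the step of a 59-fold higher number from compound 1 to compound 3 (1.77 log units; beyond the scatter) shows that a large loss at this aromatic carbon does not depend on carboxy, since 1,3,4-oxadiazol-2-yl, with no hydrogen-bond donors and no net charge, also brings one. Replacing carboxy with this group still recovers part of that loss, giving a 9.5-fold lower number from compound 2 to compound 3 (0.98 log units; beyond the scatter) as the step. Nothing available explains either step. The compounds shown leave open whether the loss follows the size of the entering group or its hydrogen-bond acceptors. They also leave open whether a methyl, a chlorine or an amine here would stay close to compound 1.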